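The source may report more compounds than this note shows. Statements on the series, on what has been measured and on what is new or still open speak of the compounds shown alone.

Measured compounds:
compound 1, `Cc1nn(C(C)(C)C)c2nc(C(C)C)c(/C=C/[C@@H](O)C[C@@H](O)CC(=O)O)c(-c3ccc(F)cc3)c12` — 51.8%
compound 2, `Cc1nn(Cc2ccccc2)c2nc(C(C)C)c(/C=C/[C@@H](O)C[C@@H](O)CC(=O)O)c(-c3ccc(F)cc3)c12` — 16.4%

Among the measured compounds shown here, in an in vivo functional assay on the whole organism for inhibition of 3-hydroxy-3-methylglutaryl-coenzyme A reductase (Rattus norvegicus), at a dose of 0.2 mg/kg by the oral route (on this read-out lower numbers stand for a weaker effect and higher numbers for a stronger effect at the one dose given), compound 2 gives 16.4%, the lower of the two numbers known here; the only other measured compound, compound 1, stands higher in this assay at 51.8%, and the single measured step, a number 35.4 percentage points lower from compound 1 to compound 2 (beyond the scatter), shows that what sits on the aromatic nitrogen of the shared core matters a great deal for this read-out.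

Compound 3, `COc1ccc(-n2nc(C)c3c(-c4ccc(F)cc4)c(/C=C/[C@@H](O)C[C@@H](O)CC(=O)O)c(C(C)C)nc32)cc1`, is not yet measured. It differs from compound 2 in this way: 4-methoxyphenyl in place of benzyl on an aromatic nitrogen

For the measured compounds named here, no measured pair compares a benzyl with an aryl group directly on that nitrogen, so the one step only says that the position is sensitive, not which way the number will move. Compound 3 is therefore expected to land somewhere between the two measured values, with a step of a number 18.6 percentage points higher from compound 2 to compound 3 (beyond the scatter) as the estimate. For compound 3 the estimated result is 35%, within a range of 10% to 65%.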

Compound 3, a percentage reported as inhibition, in the whole organism at one dose (the size of the read-out at that dose, not a potency): -27.5%
Compound 3: the middle estimate sits 62.5 percentage points above what was measured; measured number below the stated range.
By their numbers in this assay, from the lowest: compound 3; then compound 2; then compound 1.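

At this aromatic nitrogen, the read-out can fall well past the level that benzyl gave: the change to 4-methoxyphenyl gives a number 43.9 percentage points lower from compound 2 to compound 3 (beyond the scatter), and measured against tert-butyl the same group gives a number 79.3 percentage points lower from compound 1 to compound 3 (beyond the scatter). In this assay compound 3 gives -27.5%, a number below zero, so among these three compounds the order runs from tert-butyl through benzyl to 4-methoxyphenyl, with each step beyond the scatter. Nothing available here accounts for this drop.

The change puts the ring directly on the nitrogen and also adds a methoxy group, and only a plain phenyl on that nitrogen could separate those two differences. On these data alone, it also remains open whether a methyl or an isopropyl group there would hold, raise or lower the number seen with tert-butyl.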